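Methyl for amino on the azetidine ether core

A few compounds are considered here, and "the series" means these few. Any claim that something is new, unique, unknown or untested is made for them only; others in the source may bear on it.

Measured compounds:
- compound 1 `Brc1cncc(OC[C@@H]2CCN2)c1`: 0.18 nM
- compound 2 `N#Cc1cncc(OC[C@@H]2CCN2)c1`: 0.025 nM
- compound 3 `Nc1cncc(OC[C@@H]2CCN2)c1`: 0.082 nM

In an assay on brain for binding affinity to Neuronal acetylcholine receptor; alpha4/beta2 (Rattus norvegicus), read by radioligand binding (on this read-out lower numbers stand for stronger inhibition and higher numbers for weaker inhibition), compound 3 stands second highest of the three numbers. Its nearest neighbour is compound 1, reached by a 2.2-fold lower number from compound 1 to compound 3 (0.34 log units; beyond the scatter); its furthest is compound 2, reached by a 3.3-fold higher number from compound 2 to compound 3 (0.52 log units; beyond the scatter). Compound 4 `Cc1cncc(OC[C@@H]2CCN2)c1` is not yet measured. It differs from compound 3 by methyl in place of amino on an aromatic carbon. Going by the values given here, no measured step swaps a methyl group in, so the bearing steps are only indirect: a 7.2-fold lower number from compound 1 to compound 2 (0.86 log units; beyond the scatter) and a 2.2-fold lower number from compound 1 to compound 3 (0.34 log units; beyond the scatter) show that each change at this carbon shifted the number only modestly. A modest step in either direction, or none beyond the scatter, is therefore expected for compound 4, and its value is estimated at 0.15 nM (range 0.05 nM to 0.5 nM), which corresponds to an expected 1.8-fold higher number from compound 3 to compound 4 (0.26 log units; within the scatter).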

Compound 4, inhibition constant: 0.047 nM
Beside the measured number, compound 4's estimate is 3.2-fold (0.50 log units) above it, outside the stated range (below it).
By their numbers in this assay, from the lowest: compounds 2, 4 and 3 (each within the scatter of the next, the first and the last beyond it); then compound 1.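

In this assay, the hydrogen-bond donor and acceptor of amino are not needed at this carbon: methyl carries neither, and the change gives a 1.7-fold lower number from compound 3 to compound 4 (0.24 log units; within the scatter). Methyl also matches cyano within the scatter, with a 1.9-fold higher number from compound 2 to compound 4 (0.27 log units; within the scatter), yet it clearly improves on bromo, with a 3.8-fold lower number from compound 1 to compound 4 (0.58 log units; beyond the scatter). No evidence is available to explain these steps. The compounds shown leave open how a longer chain such as ethyl, or a methoxy group or carboxylic acid, would behave at this carbon. They also leave open whether methyl would be tolerated elsewhere on the ring.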